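The source may report more compounds than this note shows. Statements on the series, on what has been measured and on what is new or still open speak of the compounds shown alone.

Compound 1 `COc1ccc(NC(=S)N/N=C\c2ccnc3ccccc23)cc1` gives 1360 nM
Compound 2 `Fc1ccc(NC(=S)N/N=C\c2ccnc3ccccc23)cc1` gives 1070 nM

In a functional assay on T47D cells (Homo sapiens) for cytotoxicity, read by MTT assay, with a stated time of 48 h (a higher number here means a weaker inhibitor, a lower number a stronger inhibitor), compound 2 and compound 1 stand within the scatter of each other, so neither can be ranked above the other. Compound 3 `O=[N+]([O-])c1ccc(NC(=S)N/N=C\c2ccnc3ccccc23)cc1` changes compound 2 in one place: nitro in place of fluoro on an aromatic carbon, para to a large group. Among the measured compounds shown here, the one measured step on this carbon, fluoro in place of methoxy, was a 1.3-fold lower number from compound 1 to compound 2 (0.10 log units; within the scatter) and is the only guide. With so little to go on, no step beyond the scatter is expected in this assay for the new change. The expected step is a 1.1-fold lower number from compound 2 to compound 3 (0.03 log units; within the scatter) and it remains only an estimate. Compound 3 is estimated at 1000 nM, with an expected range of 400 nM to 2500 nM.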

Compound 3, half-maximal inhibitory concentration: 1330 nM
Compound 3: the middle estimate sits 1.3-fold (0.12 log units) below what was measured, and the stated range covers the measured number.
By their numbers in this assay, from the lowest: compounds 2, 3 and 1 (each within the scatter of the next).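

Nitro in place of fluoro gives a 1.2-fold higher number from compound 2 to compound 3 (0.09 log units; within the scatter) and nitro in place of methoxy gives a 1.0-fold lower number from compound 1 to compound 3 (0.01 log units; within the scatter) in this assay so all three groups on this aromatic carbon now stand within the scatter of one another. Even nitro, with its larger count of heavy atoms and its two hydrogen-bond acceptors, does not separate from the other two groups here. No measured evidence accounts for this flat result.

Still open, as far as these compounds go, is whether an amine, a carboxylic acid or a longer chain on this carbon would move the number beyond the scatter. From the compounds shown here alone, whether moving any of these groups elsewhere on the ring would matter also remains unknown.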